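This account rests on a few compounds, and the source may have more. Where it says the series, first, only, none or still open, it means among the compounds named here.

Measured compounds in a functional assay on the whole organism for inhibition, with Rattus norvegicus as the target, at a dose of 3 mg/kg by the oral route; on this read-out higher numbers stand for a stronger effect at the one dose given and lower numbers for a weaker effect:
compound 1 `O=C(Nc1nn[nH]n1)c1cccc(Br)n1` gives 38%
compound 2 `O=C(Nc1nn[nH]n1)c1cc(Br)ccn1` gives 34%
compound 3 `CNc1ccc(-c2cc(C)cc(C(=O)Nc3nn[nH]n3)n2)cc1` gives 89%

Among these three numbers compound 1 stands second highest. Its nearest neighbour is compound 2, whose value lies within the usual scatter of that of compound 1, so the two cannot be told apart. Its furthest neighbour is compound 3, whose value lies beyond the scatter above that of compound 1. Compound 4 `O=C(Nc1nn[nH]n1)c1cccc(Cl)n1` has not yet been measured in this assay. It differs from compound 1 in one place: chloro in place of bromo on an aromatic carbon. For the measured compounds named here, no pair of measured compounds differs in one place only, so the size of such a step is not known from these data. The step from the bromo to the chloro compound is expected to stay within the scatter, estimated as a number 3 percentage points lower from compound 1 to compound 4 (within the scatter). Compound 4 is therefore expected to give about 35% in this assay, in a range from 15% to 55%.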

Compound 4, a percentage reported as inhibition, in the whole organism at one dose (the size of the read-out at that dose, not a potency): 18%
For compound 4 the middle estimate is 17 percentage points above the measured one; the measured number falls inside the stated range.
By their numbers in this assay, from the lowest: compound 4; then compounds 2 and 1 (each within the scatter of the next); then compound 3.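

In this assay, for the compounds shown here, chloro in place of bromo gives a number 20 percentage points lower from compound 1 to compound 4 (beyond the scatter), the first single-place step in this set, so the halogen on this aromatic carbon next to the ring nitrogen is not interchangeable. Exchanging this one atom, with no change in hydrogen-bond donors, acceptors or net charge, is enough to move the read-out beyond the usual scatter. No measurement shown here explains the difference.

The compounds shown leave open how fluoro, methoxy or an amine at this position would compare with bromo. They also leave open whether the same exchange would have a step of similar size on the core of compound 3.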